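A few compounds are considered here, and "the series" means these few. Any claim that something is new, unique, unknown or untested is made for them only; others in the source may bear on it.

Measured in a physicochemical assay for solubility, with a stated time of 24 h, tested at 30 mg/mL; a higher number here means a more soluble compound, a lower number a less soluble compound:
compound 1 `CC(=O)N1CC2(C1)CC(NS(=O)(=O)c1ccc(OCc3cc(C)nc4ccccc34)cc1)(C(=O)NO)C2`: 17000000 nM
compound 2 `Cc1cc(COc2ccc(S(=O)(=O)NC(C)(C)CC(=O)NO)cc2)c2ccccc2n1`: 1600000 nM

Compound 2, at 1600000 nM, is the lower of the two, and the gap up to compound 1 lies beyond the scatter. Compound 3 `Cc1cc(COc2ccc(S(=O)(=O)NC3(CC(=O)NO)COC3)cc2)c2ccccc2n1` is still unmeasured. Its structure departs from compound 2 as follows: a group of 9 heavy atoms (5 carbon, 1 nitrogen, 3 oxygen; one four-membered non-aromatic ring with 1 hetero atom) in place of a group of 8 heavy atoms (5 carbon, 1 nitrogen, 2 oxygen; no ring), on a sulfonamide nitrogen. The new group has one four-membered non-aromatic ring and sits on a sulfonamide nitrogen. For the measured compounds named here, no measured pair isolates a change of this kind, so any forecast is weakly anchored. Going by the values given here, the only guide is that compound 1, with 17000000 nM, stands higher in this assay than compound 2. An upward step of moderate size, beyond the scatter, is therefore expected. The expected change is a 3.1-fold higher number from compound 2 to compound 3 (0.49 log units; beyond the scatter). For compound 3 the estimated value is 5000000 nM, with an expected range from 1800000 nM to 15000000 nM.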

Compound 3, solubility: 200000 nM
For compound 3 the middle estimate is 25-fold (1.40 log units) above the measured one; the whole stated range lies above it.
By their numbers in this assay, from the lowest: compound 3; then compound 2; then compound 1.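

In this assay, on a sulfonamide nitrogen, the group with one four-membered non-aromatic ring with 1 hetero atom in place of the group with no ring gives an 8.0-fold lower number from compound 2 to compound 3 (0.90 log units; beyond the scatter), which makes compound 3 the lowest of the series in this read-out. For the compounds shown here, this is the first measured change at this position, and it runs downward even though the entering group has 3 hydrogen-bond acceptors against 2 for the group that leaves. Nothing measured here accounts for the step.

This single pair cannot separate the ring from its oxygen, so a cyclobutane in the same place would be the direct comparison. As far as these compounds go, whether an azetidine or a gem-dimethyl group with a longer chain to the hydroxamic acid would move the number either way also stays open.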